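The source may hold more compounds than are shown below. What is called first, only, known or untested is meant among the compounds shown, and "the series" means these compounds.

Measured so far:
compound 1 `N#Cc1c(N)cccc1Sc1ccccc1Cl`: 33000 nM
compound 2 `N#Cc1c(N)cccc1Sc1ccccc1Br`: 41000 nM
compound 3 `N#Cc1c(N)cccc1S(=O)(=O)c1cccc(Cl)c1`: > 200000 nM

In a functional assay on MT4 cells (Homo sapiens) for cytotoxicity (on this read-out lower numbers stand for stronger inhibition and higher numbers for weaker inhibition), compound 1 gives 33000 nM and compound 2 gives 41000 nM, so the change bromo in place of chloro on an aromatic carbon produces a 1.2-fold higher number from compound 1 to compound 2 (0.09 log units; within the scatter). For compound 3 only a limit of the assay is reported, > 200000 nM, and the difference between the core of compound 3 and the core of compound 1 is not broken down here. Compound 4 `N#Cc1c(N)cccc1S(=O)(=O)c1cccc(Br)c1` carries the same kind of change, (bromo in place of chloro on an aromatic carbon), though here the place is meta to a large group rather than ortho to it. Since compound 3 already sits at the limit of > 200000 nM in this assay, at which 1 of the 3 values shown sits, compound 4 is expected to fall there as well, with the step from compound 3 to compound 4 estimated as a step that the limit leaves unreadable from compound 3 to compound 4. Compound 4 is therefore estimated at 250000 nM, between 120000 nM and 600000 nM.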

Compound 4, half-maximal inhibitory concentration: > 200000 nM
Compound 4 was reported as a limit (the forecaster's own chance of this, stated with the estimate: 75%); the middle value lies beyond the limit too.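

Compound 3 and compound 4 are both reported only as a limit, so the step between them cannot be read: the limit of > 200000 nM in this assay, at which 2 of the 4 values shown sit.

The compounds shown leave open whether bromo in place of chloro changes the read-out on the core of compound 3.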